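Furan for phenyl on the pyrrolopyrimidine nucleoside series

This account rests on a few compounds, and the source may have more. Where it says the series, first, only, none or still open, it means among the compounds named here.

Measured compounds:
- compound 1, `COc1ncnc2c1c(-c1ccccc1)cn2[C@@H]1O[C@H](CO)[C@@H](O)[C@H]1O`: > 20000 nM
- compound 2, `CNc1ncnc2c1c(-c1ccccc1)cn2[C@@H]1O[C@H](CO)[C@@H](O)[C@H]1O`: > 20000 nM
- compound 3, `COc1ncnc2c1c(-c1ccoc1)cn2[C@@H]1O[C@H](CO)[C@@H](O)[C@H]1O`: 2820 nM

In a functional assay on K562 cells (Homo sapiens), read by MTT assay, with a stated time of 72 h (on this read-out higher numbers stand for weaker inhibition and lower numbers for stronger inhibition), compound 2 gives only a limit, > 20000 nM, and no number. Compound 1 likewise stops at a limit, > 20000 nM. This is the limit of > 20000 nM in this assay, at which 2 of the 3 values shown sit, so the step that the two limits leave unreadable from compound 1 to compound 2 cannot be read. Among the compounds with values here, compound 3 is the one numbered value, 2820 nM, and the step of an at least 7.0-fold lower number from compound 1 to compound 3 (0.85 log units; beyond the scatter) shows that a five-membered oxygen aromatic ring in place of phenyl on the shared core moves the number well beyond the scatter.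

Compound 4, `CNc1ncnc2c1c(-c1cc3ccccc3o1)cn2[C@@H]1O[C@H](CO)[C@@H](O)[C@H]1O`, is not yet measured. It differs from compound 2 by 1-benzofuran-2-yl in place of phenyl on an aromatic carbon. Within the data shown here, the only measured step that bears on it is an at least 7.0-fold lower number from compound 1 to compound 3 (0.85 log units; beyond the scatter), which concerns a furan-3-yl rather than a 1-benzofuran-2-yl and starts from the methoxy rather than the methylamino compound. Since compound 2 sits at a limit, the step of an at least 5.0-fold lower number from compound 2 to compound 4 (0.69 log units; beyond the scatter) expected here is a move downward of unknown size, set in line with the furan result. Compound 4 is therefore estimated at 4000 nM, within 600 nM to 20000 nM, with a real chance that this assay again reports only a limit.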

Compound 4, half-maximal inhibitory concentration: > 20000 nM
Compound 4 was reported as a limit (the forecaster's own chance of this, stated with the estimate: 35%); middle value at least 5.0-fold (0.69 log units) away from the limit.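

In this assay compound 4 gives > 20000 nM, a limit and not a number. With compound 2 also at a limit, no step from compound 2 to compound 4 can be read: the limit of > 20000 nM in this assay, at which 3 of the 4 values shown sit.

The compounds shown leave open whether 1-benzofuran-2-yl in place of phenyl moves the number at all, and whether furan-3-yl lowers it on the methylamino compound as on the methoxy compound.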